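The source may hold more compounds than are shown below. What is called first, only, known or untested is meant among the compounds shown, and "the series" means these compounds.

Measured so far:
compound 1, `COCCNc1nc(C)cc2c1c(N)nn2C`: 4%
compound 2, `COCCNc1nc(-c2ccccc2)cc2c1c(N)nn2C`: 1%

In an assay on isolated protein for inhibition of serine/threonine-protein kinase D2 (Homo sapiens), read by mobility shift assay, tested at 30 uM (on this read-out higher numbers stand for more inhibition at the one concentration tested (going by the name of the read-out) and lower numbers for less inhibition), compound 1 gives 4% and compound 2 gives 1%. Going by the values given here, the one measured step, a number 3 percentage points lower from compound 1 to compound 2 (within the scatter), leaves the two numbers within the usual scatter of each other, so compound 2 cannot be set apart from compound 1; both show almost no inhibition at the tested concentration.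

Compound 3, `Cn1nc(N)c2cnc(-c3ccccc3)cc21`, differs from compound 2 in one place: hydrogen in place of (2-methoxyethyl)amino on an aromatic carbon. Among the compounds with values here, no measured pair touches this group; the only step in hand, a number 3 percentage points lower from compound 1 to compound 2 (within the scatter), concerns a different position, and it was itself within the scatter. There is therefore nothing in the data to point to a shift in this assay in either direction, and with compound 2 already near the floor of the read-out, a step beyond the scatter is not expected. The step from compound 2 to compound 3 is estimated as a number 1 percentage points higher from compound 2 to compound 3 (within the scatter). For compound 3 the expected value in this assay is 2%, with a range from -8% to 12%.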

Compound 3, a percentage reported as inhibition, at one concentration (the size of the read-out at that concentration, not a potency): 5%
Compound 3: middle estimate off by 3 percentage points, on the low side; the measured number falls inside the stated range.
By their numbers in this assay, from the lowest: compounds 2, 1 and 3 (each within the scatter of the next).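

In this assay, the change at the carbon next to the ring nitrogen gives a number 4 percentage points higher from compound 2 to compound 3 (within the scatter) as hydrogen replaces (2-methoxyethyl)amino, the first step shown at this position. With the phenyl group kept in place, the read-out therefore does not separate a compound that carries the (2-methoxyethyl)amino chain from one that has only hydrogen there, and nothing shows that the chain adds to or takes away from inhibition at the one concentration tested. Nothing on hand bears on why the numbers fall as they do.

Going by these compounds, all three compounds sit close to the bottom of the read-out, so it remains open whether any group at this position can lift inhibition clearly above the scatter, for instance a piperazine, a carboxylic acid or a longer ether chain. On these data alone, it is also open whether hydrogen in place of (2-methoxyethyl)amino would read the same with methyl rather than phenyl on the shared core, or in a compound that shows real inhibition in this assay to begin with.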